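Fluoro removal on the phenyl ring across two hydrazide cores

This account rests on a few compounds, and the source may have more. Where it says the series, first, only, none or still open, it means among the compounds named here.

Compound 3 `O=C(N/N=C/c1ccccc1O)c1ccc(-c2ccc(F)cc2F)o1` gives 9600 nM in a functional assay on BGC-823 cells (Homo sapiens) for antiproliferative activity, read by sulforhodamine B assay, with a stated time of 48 h; on this read-out lower numbers stand for stronger inhibition and higher numbers for weaker inhibition. Compound 1 `O=C(N/N=C/c1ccccc1O)c1ccc(-c2ccc(F)cc2)o1` differs from it by hydrogen in place of fluoro on an aromatic carbon, and in this assay compound 1 gives 180000 nM; the step is a 19-fold higher number from compound 3 to compound 1 (1.27 log units; beyond the scatter). Compound 2 `O=C(N/N=C/c1ccc(-c2ccc(F)cc2F)o1)c1ccccc1O` has the same atoms as compound 3 joined differently; the difference between the two cores is not broken down here. In this assay compound 2 gives 46600 nM. Compound 4 `O=C(N/N=C/c1ccc(-c2ccc(F)cc2)o1)c1ccccc1O` differs from compound 2 by hydrogen in place of fluoro on an aromatic carbon, the same change at the same place as between compound 3 and compound 1. For compound 4 the expected step in this assay is an 11-fold higher number from compound 2 to compound 4 (1.03 log units; beyond the scatter), resting on a 19-fold higher number from compound 3 to compound 1 (1.27 log units; beyond the scatter). The cores differ, and the expected range is kept wide. Compound 4 is therefore estimated at 500000 nM, expected between 100000 nM and 2000000 nM.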

Compound 4, half-maximal inhibitory concentration: 9500 nM
Beside the measured number, compound 4's estimate is 53-fold (1.72 log units) above it, outside the stated range (below it).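

In this assay, going from 2,4-difluorophenyl to 4-fluorophenyl gives a 4.9-fold lower number from compound 2 to compound 4 (0.69 log units; beyond the scatter), so the change does not run the same way on the two cores: the same change on two cores in this assay, a 19-fold higher number (1.27 log units; beyond the scatter) from compound 3 to compound 1 and a 4.9-fold lower number (0.69 log units; beyond the scatter) from compound 2 to compound 4, 92-fold (1.96 log units) apart, beyond the scatter of two such steps

The result seen on the core of compound 3 therefore cannot be carried over to the core of compound 2 in this series. It does not show why the two cores part, and a single pair on each core gives no general rule for either one.

Still open, as far as these compounds go, is whether the opposite directions persist when a chloro or methoxy group replaces the fluoro at that place. Also open, from the compounds shown here alone, is what a phenyl ring with no fluoro gives on either core.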